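Series notes: iodo in place of methoxy on the ring

The source may hold more compounds than are shown below. What is called first, only, known or untested is meant among the compounds shown, and "the series" means these compounds.

Measured so far in an ADME assay on the whole organism with Oryza sativa as the target, tested at 1 uM; a higher number here means a weaker effect of the compound at the concentration tested, a lower number a stronger effect:
compound 1 `CCCCCCCc1ccc(NC(=O)N[C@@H](C)c2ccccc2)cc1` gives 99%;
compound 2 `COc1cccc(NC(=O)N[C@H](C)c2ccccc2)c1` gives 92%;
compound 3 `COc1cccc(NC(=O)N[C@@H](C)c2ccccc2)c1` gives 99%.

Compound 3 stands level with compound 1 at the digits shown in this assay. Among the compounds with values here, its only measured neighbour is compound 2, from which it differs by a number 7 percentage points higher from compound 2 to compound 3 (within the scatter); that step rests on the fact that compounds 2 and 3 differ only in the configuration as drawn and on nothing else. Compound 4 `C[C@H](NC(=O)Nc1cccc(I)c1)c1ccccc1` differs from compound 3 by iodo in place of methoxy on an aromatic carbon. Within the data shown here, no measured step exchanges one group for another on that ring, so the single measured step, a change of configuration within the scatter, offers no guidance on size or direction here; all three measured values lie close together. The step of a number 4 percentage points lower from compound 3 to compound 4 (within the scatter) is therefore expected to stay within the scatter. Compound 4 is estimated to give 95%, within 80% to 100%.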

Compound 4, a percentage reported as activity, at one concentration (the size of the read-out at that concentration, not a potency): 95%
Compound 4: the middle estimate sits on the measured number at the digits printed, and the stated range covers the measured number.
By their numbers in this assay, from the lowest: compounds 2, 4, 1 and 3 (each within the scatter of the next).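

In this assay, within the data shown here, iodo in place of methoxy gives a number 4 percentage points lower from compound 3 to compound 4 (within the scatter) and is the first measured exchange of one group for another on this ring, at the place meta to a large group. In this pair, a group that counts a hydrogen-bond acceptor and a group that counts none therefore stand within the scatter of each other. The available evidence does not bear on this exchange.

As far as these compounds go, whether an amine, a carboxylic acid or a longer chain at this place would give a step beyond the scatter stays open. So does how iodo reads with the other configuration as drawn at the saturated chain carbon.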